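Removing the Methoxy from the Pyridyl Ring

The source may hold more compounds than are shown below. What is called first, only, known or untested is meant among the compounds shown, and "the series" means these compounds.

Compound 3 `COc1cc(-c2nc(C(c3ccc(F)cc3)c3ccc(F)cc3)sc2CC(=O)O)ccn1` carries a 2-methoxypyridin-4-yl group on the shared core. In an in vitro functional assay on HEK285-7 cells for antagonist activity at prostaglandin D2 receptor 2 (Homo sapiens), read by BRET and beta-arrestin recruitment (a higher number here means a weaker inhibitor, a lower number a stronger inhibitor), compound 3 gives 380 nM, the higher of the two numbers recorded in this series; the nearest is compound 1 `O=C(O)Cc1sc(C(c2ccc(F)cc2)c2ccc(F)cc2)nc1-c1ccco1`, which in this assay gives 140 nM, so that the step is a 2.7-fold higher number from compound 1 to compound 3 (0.43 log units; beyond the scatter). Compound 2 `O=C(O)Cc1sc(C(c2ccc(F)cc2)c2ccc(F)cc2)nc1-c1ccnc(N2CCCC2)c1`, bearing 2-(pyrrolidin-1-yl)pyridin-4-yl, returns in this assay only > 100000 nM, which is a limit of the assay and not a number. The steps of an at least 710-fold higher number from compound 1 to compound 2 (2.85 log units; beyond the scatter) and an at least 260-fold lower number from compound 2 to compound 3 (2.42 log units; beyond the scatter) are therefore bounded by that limit.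

Compound 4 `O=C(O)Cc1sc(C(c2ccc(F)cc2)c2ccc(F)cc2)nc1-c1ccncc1` differs from compound 3 by hydrogen in place of methoxy on an aromatic carbon. Of the measured steps, an at least 260-fold lower number from compound 2 to compound 3 (2.42 log units; beyond the scatter) bears most directly on it, since a smaller group at the same place brought a far lower number, while a 2.7-fold higher number from compound 1 to compound 3 (0.43 log units; beyond the scatter) shows the methoxy-bearing ring already trailing the furan. On that basis a small step downward or none beyond the scatter is expected. Compound 4 is estimated at 250 nM, between 80 nM and 800 nM, which is expected to be a step of a 1.5-fold lower number from compound 3 to compound 4 (0.18 log units; within the scatter).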

Compound 4, half-maximal inhibitory concentration: 40 nM
Beside the measured number, compound 4's estimate is 6.3-fold (0.80 log units) above it; the measured number lies below the stated range.
By their numbers in this assay, from the lowest: compound 4; then compound 1; then compound 3. At a limit, above all of these: compound 2.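

Removing the methoxy from the ring gives a 9.5-fold lower number from compound 3 to compound 4 (0.98 log units; beyond the scatter), so on this aromatic carbon next to the ring nitrogen, hydrogen serves better than either group tried before. The bare pyridin-4-yl ring also overtakes the furan-2-yl group, with a 3.5-fold lower number from compound 1 to compound 4 (0.54 log units; beyond the scatter), which reverses the order seen with the methoxy-bearing ring. Compound 2 stands at a limit of the assay and not at a number, so an at least 2500-fold lower number from compound 2 to compound 4 (3.39 log units; beyond the scatter) is only a bound: the limit of > 100000 nM in this assay, at which 1 of the 4 values shown sits.

The compounds shown leave open whether any group at this place can match hydrogen, for instance fluorine, methyl or a hydroxyl. They also leave open whether a small open-chain amine such as dimethylamino would fall as far as the pyrrolidin-1-yl group does, or whether the loss belongs to that ring.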